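A few compounds are considered here, and "the series" means these few. Any claim that something is new, unique, unknown or untested is made for them only; others in the source may bear on it.

Working notes on the series.

Compound 1 `CC(C)N1C(=O)C(Cc2ccc(F)cc2)COC12C=CC(=O)C=C2` and compound 2 `CC(C)N1C(=O)C(Cc2ccc(C(F)(F)F)cc2)COC12C=CC(=O)C=C2` share one core; compound 3 `CN1C(=O)C(CCNc2cc(C(F)(F)F)cc(C(F)(F)F)c2)COC12C=CC(=O)C=C2` carries a different core, and the difference between the two cores is not broken down here. In an assay on isolated protein for inhibition of N-lysine methyltransferase SMYD2 (Homo sapiens), read by filter binding, with a stated time of 1 h (on this read-out lower numbers stand for stronger inhibition and higher numbers for weaker inhibition), compound 1 gives only a limit, > 20000 nM. In this assay compound 2 likewise gives only a limit, > 20000 nM. The step that the two limits leave unreadable from compound 2 to compound 1 therefore cannot be read, since both values sit at the limit of > 20000 nM in this assay, at which 2 of the 3 values shown sit; the change is fluoro in place of trifluoromethyl on an aromatic carbon. In this assay, among the measured compounds shown here, compound 3 gives 2130 nM, the only number in the set.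

Compound 4 `CN1C(=O)C(CCNc2cc(F)cc(C(F)(F)F)c2)COC12C=CC(=O)C=C2` is not yet measured. It arises from compound 3 by fluoro in place of trifluoromethyl on an aromatic carbon, the same kind of change as that from compound 2 to compound 1, though here the place is meta to a large group and meta to a trifluoromethyl group rather than para to a large group. The earlier step gives no readable size, so the expectation rests on compound 3 at 2130 nM alone, with the step of a 2.3-fold higher number from compound 3 to compound 4 (0.37 log units; beyond the scatter) expected toward weaker inhibition. Compound 4 is estimated at 5000 nM, within 2000 nM to 20000 nM.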

Compound 4, half-maximal inhibitory concentration: 7520 nM
For compound 4 the middle estimate is 1.5-fold (0.18 log units) below the measured one; the measured number falls inside the stated range.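

In this assay, fluoro in place of trifluoromethyl on the core of compound 3 gives a 3.5-fold higher number from compound 3 to compound 4 (0.55 log units; beyond the scatter), so on this core the change weakens inhibition modestly. The same change on the core of compound 1 cannot be read, because compound 1 and compound 2 each give only a limit of the assay: (the limit of > 20000 nM in this assay, at which 2 of the 4 values shown sit). Whether the change carries from one core to the other is therefore not shown, as only one readable step stands, and it gives neither size nor direction for the core of compound 1.

As far as these compounds go, how a nitrile or a chloro group would compare with fluoro at this place stays open. So does the effect of a longer chain in place of the chain bearing the aromatic amine.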